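The compounds below may be only part of what the source reports. "The series", "measured", "known", "first", "only" and "open" are said of these compounds alone.

Of the compounds shown here, three built on one shared core have been measured in an ADME assay on L929 cells (Mus musculus) for cytotoxicity, read by resazurin assay, with a stated time of 72 h; a higher number here means a weaker inhibitor, a lower number a stronger inhibitor. Compound 1 `OB1OCc2ccc(-n3ccc4ccccc43)cc21` gives in this assay a value of > 10 ug/mL, which is a limit of the assay rather than a number. Compound 2 `OB1OCc2ccc(-n3cccc3)cc21` gives in this assay > 10 ug/mL, again a limit. Compound 3 `CC(=O)c1ccn(-c2ccc3c(c2)B(O)OC3)c1` gives in this assay > 10 ug/mL, also a limit. The only measured step among these, a step that the two limits leave unreadable from compound 2 to compound 3, cannot be sized because of the limit of > 10 ug/mL in this assay, at which 3 of the 3 values shown sit. Compound 3 therefore stands at the limit, like the two others, with no number to place it more finely.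

Compound 4 `NCc1ccc(C(=O)c2ccn(-c3ccc4c(c3)B(O)OC4)c2)cc1` has not been measured. It differs from compound 3 by 4-(aminomethyl)phenyl in place of methyl on a carbonyl carbon. Within the data shown here, no measured step bears directly on this change, and the one step that exists is unreadable, so nothing in the data points toward a step beyond the scatter in either direction. The step that the limit leaves unreadable from compound 3 to compound 4 is expected to be small. Compound 4 is expected to give 15 ug/mL in this assay, within a range from 5 ug/mL to 50 ug/mL, most likely reported again as a limit.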

Compound 4, half-maximal inhibitory concentration: > 10 ug/mL
Compound 4 gave a limit, no number (the forecaster's own chance of this, stated with the estimate: 70%); the middle value lies beyond the limit too.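

No step can be read from compound 3 to compound 4, because both values are limits of the assay, not numbers: the limit of > 10 ug/mL in this assay, at which 4 of the 4 values shown sit. The compounds shown leave open where any of them truly lies past that limit, and so what 4-(aminomethyl)phenyl in place of methyl does to the value.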